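The source may hold more compounds than are shown below. What is called first, only, known or untested is meant among the compounds shown, and "the series" means these compounds.

Three measured compounds and one still to be tested share a common design. In an assay on HEK293-A cells with putative P2Y purinoceptor 10 (Mus musculus) as the target, with a stated time of 1.5 h (on this read-out lower numbers stand for smaller maximal responses and higher numbers for larger maximal responses), compound 1 `CCCCCCCCCCCOc1ccccc1CCC(=O)OCc1ccccc1OP(=O)(O)OC[C@H](N)C(=O)O` gives 0.02. Compound 2 `Cc1ccc(Oc2cccc(COc3ccccc3CCC(=O)O[C@@H]3CCCO[C@@H]3COP(=O)(O)OC[C@H](N)C(=O)O)c2)cc1` is reported in this assay as "not active" (no number reported), and compound 3 `N[C@@H](COP(=O)(O)O[C@@H]1C=CCO[C@@H]1COC(=O)CCc1ccccc1OCc1cccc(Oc2ccccc2)c1)C(=O)O` is reported in this assay as "not active" (no number reported). Compound 3 therefore stands without a single number, and compound 2 is the one other entry in the same position. The next compound is compound 4 `N[C@@H](COP(=O)(O)O[C@H]1C=CCO[C@@H]1COC(=O)CCc1ccccc1OCc1cccc(Oc2ccccc2)c1)C(=O)O`. Among the measured compounds shown here, its only change from compound 3 is the two compounds have the same atoms and bonds; at least one stereo element is drawn with a configuration in one of them and without one in the other: 1 of 4 stereo elements differ; a stereocentre at a saturated ring carbon is drawn R in compound 3 and S in compound 4. For the measured compounds named here, no measured pair shows what such a change does, so nothing points to a shift beyond the usual scatter of this assay in either direction, and a report of no activity again seems the likeliest outcome. Since compound 3 gives "not active" (no number reported), compound 4 is expected to give about 0.03, within a range of 0 to 0.15.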

Compound 4, intrinsic activity: the largest response reached, as a fraction of the reference agonist's: 0.0053
Estimate against measurement, compound 4: 0.025 above; the measured number falls inside the stated range.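

Compound 3 has no number, only a report of no activity, and compound 4 gives 0.0053; no step can be read between them. Whether the configuration at that saturated ring carbon changes the maximal response stays open, and one caution applies: the fact that one of compounds 3 and 4 is drawn with a defined configuration and the other without, at the place where they differ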